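Trimming the amide to a methyl in a pancreatic cancer cell assay

The source may report more compounds than this note shows. Statements on the series, on what has been measured and on what is new or still open speak of the compounds shown alone.

Of the compounds shown here, three have been measured in a functional assay on MIA PaCa-2 cells (Homo sapiens) for inhibition, read by MTT assay, with a stated time of 7 days; on this read-out lower numbers stand for stronger inhibition and higher numbers for weaker inhibition. Compound 1 `CCN(CC)C(=O)[C@@H]1CCCN(S(=O)(=O)c2ccc(S(=O)(=O)N(CC)CC)cc2)C1` gives 6400 nM, compound 2 `CCN(CC)S(=O)(=O)c1ccc(S(=O)(=O)N2CCC[C@@H](C(=O)NC3CN(C(=O)NC(C)(C)C)C3)C2)cc1` gives 3400 nM, and compound 3 `CCOC(=O)C1CCCCN1S(=O)(=O)c1ccc(S(=O)(=O)N(CC)CC)cc1` gives 24600 nM. Compound 2 shows the lowest number of the three, but its gap to compound 1 is small, and only compound 3 lies clearly apart from it.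

Compound 4 `CCN(CC)S(=O)(=O)c1ccc(S(=O)(=O)N2CCC[C@@H](C(=O)NC)C2)cc1` is not yet measured. It differs from compound 2 in one place: methyl in place of 1-((tert-butyl)carbamoyl)azetidin-3-yl on an amide-type nitrogen. Within the data shown here, the only measured step that touches the same amide nitrogen is the one between compound 1 and compound 2, which reads a 1.9-fold lower number from compound 1 to compound 2 (0.27 log units; within the scatter). Replacing a small group with a much larger one there barely moved the number, so removing the large group again in compound 4 is expected to change little, perhaps drifting back toward compound 1 because that compound, with its smaller amide, gave 6400 nM.

Compound 4 is therefore expected to show a step of a 1.8-fold higher number from compound 2 to compound 4 (0.25 log units; within the scatter). The estimate for compound 4 is 6000 nM, with a range from 2500 nM to 15000 nM.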

Compound 4, half-maximal inhibitory concentration: 8600 nM
For compound 4 the middle estimate is 1.4-fold (0.16 log units) below the measured one; low and high end bracket the measured number.
By their numbers in this assay, from the lowest: compounds 2, 1 and 4 (each within the scatter of the next, the first and the last beyond it); then compound 3.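

In this assay, the change at this amide-type nitrogen now shows a difference beyond the scatter: methyl in place of 1-((tert-butyl)carbamoyl)azetidin-3-yl gives a 2.5-fold higher number from compound 2 to compound 4 (0.40 log units; beyond the scatter) as a modest step. The other step at this amide, methylamino in place of diethylamino, reads a 1.3-fold higher number from compound 1 to compound 4 (0.13 log units; within the scatter) and so does not separate these two amides. The data shown offer no measured reason for either step.

Still open is which part of the 1-((tert-butyl)carbamoyl)azetidin-3-yl group accounts for the difference, the four-membered ring or the tert-butyl carbamoyl on it. Also open, as far as these compounds go, is how an ethyl chain, a cyclohexyl ring or an azetidine carrying a free amine would read on this same nitrogen in this assay when compared with methyl.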